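Benzyl Swap on the Pyrrolidinylmethyl Core, Methoxy for Chloro

The source may report more compounds than this note shows. Statements on the series, on what has been measured and on what is new or still open speak of the compounds shown alone.

In an assay for binding affinity to Alpha-1B adrenergic receptor (Homo sapiens) (on this read-out lower numbers stand for stronger inhibition and higher numbers for weaker inhibition), compound 1 `CN1CCC[C@@H]1Cn1nc(Cc2cccc(Cl)c2)c2ccccc2c1=O` gives 631 nM, the highest of the two numbers reported. Its nearest neighbour, compound 2 `CN1CCC[C@@H]1Cn1nc(Cc2cccc(F)c2)c2ccccc2c1=O`, gives 398 nM; the step of a 1.6-fold lower number from compound 1 to compound 2 (0.20 log units; within the scatter) stays within the scatter. For compound 3 `COc1ccc(Cc2nn(C[C@H]3CCCN3C)c(=O)c3ccccc23)cc1OC` the assay reports only a limit, > 1990 nM. Compound 4 `COc1ccc(Cc2nn(C[C@H]3CCCN3C)c(=O)c3ccccc23)cc1` has not yet been measured; it differs from compound 1 by 4-methoxyphenyl in place of 3-chlorophenyl on a saturated chain carbon bound to an aromatic carbon. Going by the values given here, the single measured step, fluoro for chloro, concerns another position and says little about this change. Because the limit of > 1990 nM in this assay, at which 1 of the 3 values shown sits, shows a methoxy-bearing relative of compound 4 beyond the upper bound, a weaker number is expected for compound 4, estimated at 1500 nM (range 500 nM to 4500 nM), a step of a 2.4-fold higher number from compound 1 to compound 4 (0.38 log units; beyond the scatter).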

Compound 4, inhibition constant: 158 nM
The estimate for compound 4 lay 9.5-fold (0.98 log units) above the measured number; the measured number lies below the stated range.
By their numbers in this assay, from the lowest: compound 4; then compounds 2 and 1 (each within the scatter of the next). At a limit, above all of these: compound 3.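

Changing the benzyl group on this saturated chain carbon moves the number beyond the scatter, with a 4.0-fold lower number from compound 1 to compound 4 (0.60 log units; beyond the scatter) and a 2.5-fold lower number from compound 2 to compound 4 (0.40 log units; beyond the scatter), whereas the fluoro for chloro swap did not. Methoxy-bearing compounds do not all fall on the weak side, as hydrogen in place of methoxy on an aromatic carbon gives an at least 12-fold lower number from compound 3 to compound 4 (1.10 log units; beyond the scatter). The value for compound 3 is only a limit: the limit of > 1990 nM in this assay, at which 1 of the 4 values shown sits.

Going by these compounds, whether the lower number follows from the methoxy group or from its place on the ring stays open. On these data alone, a 3-methoxybenzyl or 4-chlorobenzyl group would separate the two, and how a 4-aminobenzyl group would read is also open.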